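A few compounds are considered here, and "the series" means these few. Any claim that something is new, unique, unknown or untested is made for them only; others in the source may bear on it.

Measured compounds:
compound 1, `COc1ccc(-c2nc(Nc3ccccc3)sc2CC(=O)O)cc1`: 1900 nM
compound 2, `O=C(O)Cc1sc(Cc2ccc(Cl)cc2)nc1-c1ccccc1`: 88 nM

Both numbers come from an in vitro assay on COS-7 cells for displacement of a labelled ligand from prostaglandin D2 receptor 2 (Homo sapiens); a lower number here means a stronger inhibitor, a higher number a weaker inhibitor. Compound 2 stands with the lowest of the two numbers; compound 1 gives the higher number, and the gap between them lies beyond the usual scatter. For the measured compounds named here, compound 1 and compound 2 differ from each other in more than one place, so the two values show only that compound 2 is the stronger inhibitor of the pair, not which part of the structure carries the difference.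

Compound 3, `COc1ccc(-c2nc(Cc3ccc(Cl)cc3)sc2CC(=O)O)cc1`, has not yet been measured. It follows from compound 2 by a single change: methoxy in place of hydrogen on an aromatic carbon. The rest of compound 2 is kept. Going by the values given here, no measured pair shows this change on its own; compound 1 carries the methoxy group but differs elsewhere as well, so it gives no guide to the size of the step. The expected step is a 1.1-fold higher number from compound 2 to compound 3 (0.06 log units; within the scatter), small, in no clear direction and probably not beyond the scatter. For compound 3 the estimated value in this assay is 100 nM, with a range from 30 nM to 400 nM.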

Compound 3, half-maximal inhibitory concentration: 360 nM
Compound 3: middle estimate off by 3.6-fold (0.56 log units), on the low side, and the stated range covers the measured number.
By their numbers in this assay, from the lowest: compound 2; then compound 3; then compound 1.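

In this assay, methoxy in place of hydrogen on an aromatic carbon, para to a large group, is not a neutral change: phenyl to 4-methoxyphenyl gives a 4.1-fold higher number from compound 2 to compound 3 (0.61 log units; beyond the scatter). With the 4-methoxyphenyl group held constant, 4-chlorobenzyl in place of anilino gives a 5.3-fold lower number from compound 1 to compound 3 (0.72 log units; beyond the scatter), so each of the two places in which compound 1 and compound 2 differ now has its own step beyond the scatter, and the direction of each step is known. No measurement available here bears on the origin of either step.

The compounds shown leave open whether the higher number follows from methoxy in particular or from any group at this carbon; fluorine, methyl, hydroxyl or ethoxy at the same place would separate these readings. They also leave open whether methoxy in place of hydrogen gives a step of similar size when anilino stands in place of 4-chlorobenzyl, since one step on one pair cannot show how the two places act together.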